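The compounds below may be only part of what the source reports. "The series", "measured", "known", "first", "only" and "open" are said of these compounds alone.

Compound 1 `Cc1noc(C)c1S(=O)(=O)N1CCC(N2CCC(C)CC2)CC1` — > 10000 nM
Compound 2 `CC1CCN(C2CCN(S(=O)(=O)c3cccc(-c4ccc5ccccc5c4)c3)CC2)CC1` — > 5000 nM

In an ADME assay on HCT-116 cells (Homo sapiens) for cytotoxicity, read by CellTiter-Glo, with a stated time of 72 h (on this read-out higher numbers stand for weaker inhibition and lower numbers for stronger inhibition), compound 1 gives > 10000 nM, which is a limit of the assay and not a number, as recorded in the limit of > 10000 nM in this assay, at which 1 of the 2 values shown sits. Compound 1 therefore stands only at a limit on the numbers shown, with no measured value to place it against. Compound 2 gives > 5000 nM in this assay, again a limit rather than a number, as recorded in the limit of > 5000 nM in this assay, at which 1 of the 2 values shown sits. Compound 3 `CC1CCN(C2CCN(S(=O)(=O)c3ccc(Br)c(Cl)c3)CC2)CC1` has not yet been measured in this assay. It differs from compound 1 in one place: 4-bromo-3-chlorophenyl in place of 3,5-dimethyl-1,2-oxazol-4-yl on a sulfonyl sulfur. Going by the values given here, no measured step between two compounds is available to guide the change, so the expectation for this assay is a step no larger than the usual scatter, with compound 3 likely staying at a limit as compound 1 does. The expected step of a number no higher from compound 1 to compound 3 (the limit leaves the size open) is estimated to be within that scatter. Compound 3 is estimated to give 10000 nM, in a range from 3000 nM to 30000 nM.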

Compound 3, half-maximal inhibitory concentration: > 5000 nM
Compound 3: a limit, no number; the forecaster's own chance of this, stated with the estimate: 75%; the middle value is on the limit's open side.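

Compound 1 and compound 3 both stand only at limits of this assay, not at numbers, and the step between them cannot be read. The compounds shown leave open whether 4-bromo-3-chlorophenyl in place of 3,5-dimethyl-1,2-oxazol-4-yl changes the read-out at all.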